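The compounds below may be only part of what the source reports. "The series", "measured", "known", "first", "only" and "open" are said of these compounds alone.

Compound 3 `COc1cc2c(Oc3ccc(NC(=O)c4nn(-c5ccc([N+](=O)[O-])cc5)c(=O)c5ccccc45)cc3F)ccnc2cc1OCCCN1CCN(C)CC1` gives the highest number of the three compounds measured in a functional assay on MKN-45 cells (Homo sapiens) for cytotoxicity, read by MTT assay, with a stated time of 72 h (a higher number here means a weaker inhibitor, a lower number a stronger inhibitor), at 1320 nM. For comparison, compound 1 `COc1cc2c(Oc3ccc(NC(=O)c4nn(-c5ccccc5)c(=O)c5ccccc45)cc3F)ccnc2cc1OCCCN1CCN(C)CC1` gives 620 nM and compound 2 `COc1cc2c(Oc3ccc(NC(=O)c4nn(-c5ccc(Br)cc5)c(=O)c5ccccc45)cc3F)ccnc2cc1OCCCN1CCN(C)CC1` gives 350 nM, so that a 2.1-fold higher number from compound 1 to compound 3 (0.33 log units; beyond the scatter) and a 3.8-fold higher number from compound 2 to compound 3 (0.58 log units; beyond the scatter) both place compound 3 at the weak end of this small set. Compound 4 `COc1cc2c(Oc3ccc(NC(=O)c4nn(-c5ccc([N+](=O)[O-])cc5)c(=O)c5ccccc45)cc3F)ccnc2cc1OCCCN1CCC(C)CC1` differs from compound 3 only by 4-methylpiperidin-1-yl in place of 4-methylpiperazin-1-yl on a saturated chain carbon, three bonds along the chain from an oxygen on an aromatic ring. None of the three measured steps touches this part of the molecule; each concerns a substituent on the aromatic ring, and the chain terminus is the same in compounds 1, 2 and 3. For the measured compounds named here, no measured step therefore bears on the change, and no step beyond the scatter is expected in this assay, with a 1.0-fold lower number from compound 3 to compound 4 (0.01 log units; within the scatter) as the estimated outcome. Compound 4 is thus expected to give 1300 nM, within a range from 450 nM to 3800 nM.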

Compound 4, half-maximal inhibitory concentration: 1150 nM
For compound 4 the middle estimate is 1.1-fold (0.05 log units) above the measured one; low and high end bracket the measured number.
By their numbers in this assay, from the lowest: compounds 2, 1, 4 and 3 (each within the scatter of the next, the first and the last beyond it).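

In this assay, for the compounds shown here, 4-methylpiperidin-1-yl in place of 4-methylpiperazin-1-yl gives a 1.1-fold lower number from compound 3 to compound 4 (0.06 log units; within the scatter), the first measured change at this chain position, since the earlier compounds all carry the same group there. With the nitro substituent held fixed, this exchange of one ring nitrogen for carbon leaves the number within the scatter. No evidence bearing on the reason for this result is available. As far as these compounds go, whether the same exchange behaves alike with the bromo substituent of compound 2 remains open. So does the outcome with a morpholine ring or a dimethylamino group on this chain.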